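The source may report more compounds than this note shows. Statements on the series, on what has been measured and on what is new or still open speak of the compounds shown alone.

Measured in a functional assay on HepG2 cells (Homo sapiens) for cytotoxicity, read by MTT assay, with a stated time of 48 h; a lower number here means a stronger inhibitor, a higher number a weaker inhibitor:
Compound 1 `COc1cc(/C=C/C(=O)/C=C/c2nc3ccccc3n2C)ccc1O`: 2900 nM
Compound 2 `COc1cc(/C=C/C(=O)/C=C/c2nc3cc([N+](=O)[O-])ccc3n2C)ccc1O`: 3700 nM
Compound 3 `COc1cc(/C=C/C(=O)/C=C/c2nc3cc(O)ccc3n2C)ccc1O`: 3600 nM

Compound 2 sits level with the other two compounds. The gaps bear this out: a 1.3-fold higher number from compound 1 to compound 2 (0.11 log units; within the scatter), and a 1.0-fold lower number from compound 2 to compound 3 (0.01 log units; within the scatter). The remaining pair agrees, with a 1.2-fold higher number from compound 1 to compound 3 (0.09 log units; within the scatter).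

Compound 4 `COc1ccc(/C=C/C(=O)/C=C/c2nc3cc([N+](=O)[O-])ccc3n2C)cc1O` has the same atoms as compound 2, joined differently: 3-hydroxy-4-methoxyphenyl in place of 4-hydroxy-3-methoxyphenyl on a double-bonded chain carbon bound to a double-bonded chain carbon. Here 3-hydroxy-4-methoxyphenyl stands in place of 4-hydroxy-3-methoxyphenyl, on a double-bonded chain carbon bound to a double-bonded chain carbon.

For the measured compounds named here, no measured step touches this group, so the data hold no direct precedent for the swap. The three steps above exchange hydrogen, nitro or hydroxy on an aromatic carbon of the shared core, and they bear on the question only indirectly. Among these three compounds, none of those exchanges moved the number beyond the scatter. The same is therefore expected here, with no favoured direction in this assay, though with less certainty than a direct precedent would give. The estimated change is small, a 1.1-fold lower number from compound 2 to compound 4 (0.02 log units; within the scatter). For compound 4 the expected value is 3500 nM, with an estimated range from 1500 nM to 8000 nM.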

Compound 4, half-maximal inhibitory concentration: 4600 nM
For compound 4 the middle estimate is 1.3-fold (0.12 log units) below the measured one; the measured number falls inside the stated range.
By their numbers in this assay, from the lowest: compounds 1, 3, 2 and 4 (each within the scatter of the next).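

In this assay, putting 3-hydroxy-4-methoxyphenyl in place of 4-hydroxy-3-methoxyphenyl gives a 1.2-fold higher number from compound 2 to compound 4 (0.09 log units; within the scatter), and this is the first change shown in this phenyl group rather than on the shared core. The two groups hold the same atoms and the same counts of hydrogen-bond donors and acceptors, so the step changes only how the hydroxy and methoxy groups are arranged, and for this one pair that rearrangement leaves the two numbers within the scatter of each other. Nothing measured here offers an explanation for this result.

For the compounds shown here, this swap is seen only on the nitro-bearing core of compound 2, so it remains open whether the same exchange would also stay within the scatter on the unsubstituted core of compound 1 or the hydroxy-bearing core of compound 3. Also open, as far as these compounds go, is how the number would respond if this phenyl group carried something other than hydroxy and methoxy, such as an amine, a carboxylic acid or a longer chain like ethoxy.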